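One more fluoro where the readings stop at a limit

This account rests on a few compounds, and the source may have more. Where it says the series, first, only, none or still open, it means among the compounds named here.

Of the compounds shown here, two sharing one core have been tested in a functional assay on HOS cells (Homo sapiens) for antiproliferative activity, with a stated time of 72 h; a higher number here means a weaker inhibitor, a lower number a stronger inhibitor. Compound 1 is `OC[C@H]1O[C@@H](n2cnc3c(NCc4ccc(Cl)c(Cl)c4)ncnc32)[C@H](O)[C@@H]1O`. In this test compound 1 gives > 166000 nM, which is a limit of the assay and not a number. Compound 2 is `OC[C@H]1O[C@@H](n2cnc3c(NCc4ccc(F)cc4F)ncnc32)[C@H](O)[C@@H]1O`. Compound 2 gives > 166000 nM, again only a limit, so it has no readable potency to start from. Within the data shown here, the one measured step is a step that the two limits leave unreadable from compound 1 to compound 2. All the data offer is the limit of > 166000 nM in this assay, at which 2 of the 2 values shown sit.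

Compound 3, `OC[C@H]1O[C@@H](n2cnc3c(NCc4ccc(F)c(F)c4F)ncnc32)[C@H](O)[C@@H]1O`, differs from compound 2 by fluoro in place of hydrogen on an aromatic carbon. This is fluoro in place of hydrogen on an aromatic carbon, turning 2,4-difluorophenyl into 2,3,4-trifluorophenyl. The measured step gives no size for such a change, so no shift beyond the scatter is expected in this assay, and no direction can be named. The expectation rests on compound 2 and its limit of > 166000 nM. Another limit is the likeliest report. The step expected is a number no higher from compound 2 to compound 3 (the limit leaves the size open). Compound 3 is estimated at 166000 nM, with an expected range from 70000 nM to 250000 nM.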

Compound 3, half-maximal inhibitory concentration: > 166000 nM
Compound 3: only a limit was reported (the forecaster's own chance of this, stated with the estimate: 85%); the middle value sits exactly at the limit.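

In this assay, among these compounds, compound 3 gives > 166000 nM, which is a limit of the assay and not a number, so no step among compound 1, compound 2 and compound 3 can be read. The compounds shown leave open whether any readable potency exists for this series in this assay, and all the data offer is this: the limit of > 166000 nM in this assay, at which 3 of the 3 values shown sit.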